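The source may report more compounds than this note shows. Statements on the series, on what has been measured and on what is new or still open speak of the compounds shown alone.

Three compounds here share one core and differ only in the group attached to a double-bonded ring carbon. In a functional assay on NCI-H1299 cells (Homo sapiens) for antiproliferative activity, read by MTT assay, with a stated time of 72 h (on this read-out lower numbers stand for stronger inhibition and higher numbers for weaker inhibition), compound 1 `CCCCCOC1=C(C(=O)c2ccccc2)C(c2ccc(Br)cc2)N(CCCn2ccnc2)C1=O` gives 10300 nM, compound 2 `NC1=C(C(=O)c2ccccc2)C(c2ccc(Br)cc2)N(CCCn2ccnc2)C1=O` gives 169000 nM, and compound 3 `CCOc1ccc(NC2=C(C(=O)c3ccccc3)C(c3ccc(Br)cc3)N(CCCn3ccnc3)C2=O)cc1` gives 20000 nM. Compound 3 therefore stands second highest of the three numbers: its value lies close to that of compound 1, as shown by a 1.9-fold higher number from compound 1 to compound 3 (0.29 log units; within the scatter), and well apart from compound 2, as shown by an 8.5-fold lower number from compound 2 to compound 3 (0.93 log units; beyond the scatter).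

Compound 4 `O=C(C1=C(Nc2ccc(I)cc2)C(=O)N(CCCn2ccnc2)C1c1ccc(Br)cc1)c1ccccc1` keeps the whole of compound 3 except for one group on the ring that hangs from the amine nitrogen: iodo in place of ethoxy on an aromatic carbon. Of the measured steps, only an 8.5-fold lower number from compound 2 to compound 3 (0.93 log units; beyond the scatter) concerns this nitrogen, and it covers the addition of the entire 4-ethoxyphenyl group rather than a swap of one group on that ring; a 16-fold higher number from compound 1 to compound 2 (1.22 log units; beyond the scatter) concerns a different part of the molecule. Among the compounds with values here, no measured step exchanges ethoxy for iodo. With nothing pointing in either direction, a step of a 1.3-fold lower number from compound 3 to compound 4 (0.10 log units; within the scatter) is expected, within the scatter. For compound 4 the estimated value in this assay is 16000 nM, with a likely range from 5000 nM to 50000 nM.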

Compound 4, half-maximal inhibitory concentration: 19400 nM
The estimate for compound 4 lay 1.2-fold (0.08 log units) below the measured number; the range from low to high includes it.
By their numbers in this assay, from the lowest: compounds 1, 4 and 3 (each within the scatter of the next); then compound 2.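

In this assay, replacing ethoxy with iodo on an aromatic carbon para to a large group produces a 1.0-fold lower number from compound 3 to compound 4 (0.01 log units; within the scatter), so these two groups, which differ in size and atom type, cannot be told apart at this position. The ethoxy oxygen and its two carbons therefore appear not to be required for the improvement over the plain amino compound: the iodo analogue shows an 8.7-fold lower number from compound 2 to compound 4 (0.94 log units; beyond the scatter), much like an 8.5-fold lower number from compound 2 to compound 3 (0.93 log units; beyond the scatter) for the ethoxy analogue, while a 1.9-fold higher number from compound 1 to compound 4 (0.27 log units; within the scatter) places the (4-iodophenyl)amino group within the scatter of the pentyloxy group on the double-bonded ring carbon. No supporting measurement is available to explain why ethoxy and iodo give matching results here.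

On these data alone, it remains open whether the group at this place on the ring matters at all, or whether only these two happen to match, as a carboxylic acid or an amine there could give a very different number. It is equally unclear whether a longer alkoxy chain there, such as pentyloxy, would keep the number in this range.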